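The compounds below may be only part of what the source reports. "The series", "measured", "known", "first", "only" and "open" are said of these compounds alone.

Values in a functional assay on MIA PaCa-2 cells (Homo sapiens) for antiproliferative activity, read by MTT assay, with a stated time of 3 days (on this read-out higher numbers stand for weaker inhibition and lower numbers for stronger inhibition), so far:
- compound 1 `CCCCCCCCC#Cc1cn(C/C=C\CN2C(=O)c3ccccc3C2=O)c(=O)[nH]c1=O` gives 68000 nM
- compound 2 `CCCCCC#Cc1cn(C/C=C/CN2C(=O)c3ccccc3C2=O)c(=O)[nH]c1=O` gives 60000 nM
- compound 3 `CCCCCc1ccc(C#Cc2cn(C/C=C/CN3C(=O)c4ccccc4C3=O)c(=O)[nH]c2=O)cc1` gives 26000 nM

Compound 1 lies within the scatter of compound 2, and compound 3 has a lower number than compound 1, beyond the scatter. Compound 4 `CCCCC#Cc1cn(C/C=C\CN2C(=O)c3ccccc3C2=O)c(=O)[nH]c1=O` differs from compound 1 by a single change, (hydrogen in place of butyl on a saturated chain carbon, four bonds along the chain from a triple-bonded carbon), hydrogen in place of butyl on a saturated chain carbon, four bonds along the chain from a triple-bonded carbon.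

Going by the values given here, no measured step covers this change directly. The only one available is a 2.3-fold lower number from compound 2 to compound 3 (0.36 log units; beyond the scatter), a modest move that brings in 4-pentylphenyl in place of pentyl on a triple-bonded carbon, so it concerns a different kind of group. More relevant is compound 2, with pentyl and the other double-bond geometry, at 60000 nM in this assay, since that value stays within the scatter of compound 1. Two features separate that pair, so the comparison is only a weak guide. Still, neither alkyl-chain compound gives any sign of a large move.

The step expected here is a 1.1-fold lower number from compound 1 to compound 4 (0.04 log units; within the scatter), which means no change beyond the scatter is anticipated. For compound 4 the estimated value is 62000 nM, with an expected range from 30000 nM to 130000 nM (an estimate resting on very few data).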

Compound 4, half-maximal inhibitory concentration: > 100000 nM
Compound 4: no number, only a limit (the forecaster's own chance of this, stated with the estimate: 15%); middle value at least 1.6-fold (0.20 log units) away from the limit.
By their numbers in this assay, from the lowest: compound 3; then compounds 2 and 1 (each within the scatter of the next). At a limit, above all of these: compound 4.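

In this assay compound 4 gives > 100000 nM, which is a limit and not a number. Hydrogen in place of butyl on a saturated chain carbon, four bonds along the chain from a triple-bonded carbon, gives an at least 1.4-fold higher number from compound 1 to compound 4 (0.16 log units; that floor lies within the scatter), so only a floor is available for this change, and that floor does not separate the pair. This is the first comparison in the series that changes the chain alone with the double-bond geometry held fixed, and the shorter chain shows no lower number, although the true size of the step stays unknown since the read-out ends at a limit: the limit of > 100000 nM in this assay, at which 1 of the 4 values shown sits.

Going by these compounds alone, open is whether a longer chain than the one in compound 1, or an amine or a carboxylic acid at the end of the chain, would move the value in either direction. Also open, from the compounds shown here alone, is whether 4-pentylphenyl in place of pentyl, seen as a 2.3-fold lower number from compound 2 to compound 3 (0.36 log units; beyond the scatter), would give a similar step with the other double-bond geometry.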